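Dropping one chloro from compound 1: an expected small loss

The source may report more compounds than this note shows. Statements on the series, on what has been measured and on what is new or still open speak of the compounds shown alone.

Measured so far:
compound 1 `ClCc1ccc(Cn2cnc3nc(Cl)nc(Cl)c32)cc1`: 3890 nM
compound 2 `ClCc1ccc(Cn2cnc3c(Cl)nc(Cl)nc32)cc1`: 9550 nM
compound 3 `ClCc1ccccc1Cn1cnc2nc(Cl)nc(Cl)c21`: 6760 nM

In a functional assay on NCI-H226 cells (Homo sapiens) for cytotoxicity, read by sulforhodamine B assay, with a stated time of 48 h (a lower number here means a stronger inhibitor of growth, a higher number a weaker inhibitor of growth), compound 1 gives the lowest of the three numbers. Compound 3 lies close to it, within the usual scatter, so no order can be claimed there; compound 2 stands further off, beyond the scatter, giving the weaker result of that pair.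

Compound 4 `ClCc1ccc(Cn2cnc3ncnc(Cl)c32)cc1` has not been measured. It differs from compound 1 by one change: hydrogen in place of chloro on an aromatic carbon, on the carbon between two ring nitrogen atoms of the shared core. Going by the values given here, no measured pair shows this kind of change, so the direction rests on judgment alone. A modest weakening is expected, with the step from compound 1 to compound 4 estimated at a 1.7-fold higher number from compound 1 to compound 4 (0.22 log units; within the scatter). For compound 4 the expected value in this assay is 6500 nM, within a range from 2200 nM to 20000 nM.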

Compound 4, concentration for total growth inhibition: 12000 nM
Compound 4: the middle estimate sits 1.8-fold (0.27 log units) below what was measured; the range from low to high includes it.
By their numbers in this assay, from the lowest: compounds 1, 3, 2 and 4 (each within the scatter of the next, the first and the last beyond it).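

In this assay, this chloro on the carbon between two ring nitrogen atoms proves to matter: hydrogen in its place gives a 3.1-fold higher number from compound 1 to compound 4 (0.49 log units; beyond the scatter), beyond the scatter. Going by these compounds alone, this is the first comparison here of compounds that differ in one place, and it isolates the contribution of a single chloro on the shared core. Nothing available explains this loss.

From the compounds shown here alone, whether an amine or a methoxy group at this carbon would do as well as chloro remains open. So does whether removing the other chloro would have a similar effect.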